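This account rests on a few compounds, and the source may have more. Where it says the series, first, only, none or still open, it means among the compounds named here.

Notes on the series. Compound 1 `COc1ccc(C2=NN(C3=NC(=O)/C(=C4\C(=O)Nc5ccc(Br)cc54)S3)C(c3ccc(OC)cc3)C2)cc1` in a functional assay on cells (Cancer cell lines, Homo sapiens) for cytotoxicity, read by sulforhodamine B assay, with a stated time of 48 h (a higher number here means a weaker inhibitor of growth, a lower number a stronger inhibitor of growth), gives 405 nM. Compound 2 `COc1ccc(C2CC(c3ccc4ccccc4c3)=NN2C2=NC(=O)/C(=C3\C(=O)Nc4ccc(Br)cc43)S2)cc1` carries the change naphthalen-2-yl in place of 4-methoxyphenyl on a carbon with a double bond to nitrogen and in this assay compound 2 gives 210 nM; the step of a 1.9-fold lower number from compound 1 to compound 2 (0.29 log units; within the scatter) is the only measured pairing for this change and lies within the scatter. Compound 3 `COc1ccc(C2=NN(C3=NC(=O)/C(=C4\C(=O)Nc5ccccc54)S3)C(c3ccc(Cl)cc3)C2)cc1` in this assay gives 100000 nM, the highest number of the three; the difference between the core of compound 3 and the core of compound 1 is not broken down here. Compound 4 `O=C1N=C(N2N=C(c3ccc4ccccc4c3)CC2c2ccc(Cl)cc2)S/C1=C1/C(=O)Nc2ccccc21` is not yet measured. It differs from compound 3 by naphthalen-2-yl in place of 4-methoxyphenyl on a carbon with a double bond to nitrogen. This is the same kind of change as the measured one, not the same: in compound 1 the ring atom two ring bonds away bears a 4-methoxyphenyl group, in compound 3 it bears a 4-chlorophenyl group. In this assay a similarly small step is expected, a 1.7-fold lower number from compound 3 to compound 4 (0.22 log units; within the scatter), resting on the same change having given a 1.9-fold lower number from compound 1 to compound 2 (0.29 log units; within the scatter). Going by the values given here, no measured pair shows whether that carries over to the core of compound 3, and the number for compound 3 may itself be a ceiling of what is reported. Compound 4 is therefore estimated at 60000 nM, with a range from 15000 nM to 100000 nM.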

Compound 4, concentration for total growth inhibition: 27300 nM
Beside the measured number, compound 4's estimate is 2.2-fold (0.34 log units) above it, within the range that was stated.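

In this assay the new pair shows a 3.7-fold lower number from compound 3 to compound 4 (0.56 log units; beyond the scatter) and, set beside the earlier pair, the change naphthalen-2-yl in place of 4-methoxyphenyl cannot be told apart in size on the two cores: the same change on two cores in this assay, a 1.9-fold lower number (0.29 log units; within the scatter) from compound 1 to compound 2 and a 3.7-fold lower number (0.56 log units; beyond the scatter) from compound 3 to compound 4, 1.9-fold (0.28 log units) apart, within the scatter of two such steps. Going by these compounds alone, this shows the change carrying over between these two cores with no difference beyond the scatter, although only the step on the core of compound 3 is itself beyond the scatter. It does not show a general rule, since it rests on two pairs and the cores of compound 1 and compound 3 differ in more than one place, so no single core difference is tested. The compounds shown leave open what each of those core differences contributes on its own. They also leave open what an amine or a carboxylic acid would give in place of naphthalen-2-yl on the carbon with a double bond to nitrogen.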